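Estimating a thiourea analogue of compound 1

A few compounds are considered here, and "the series" means these few. Any claim that something is new, unique, unknown or untested is made for them only; others in the source may bear on it.

The measured compounds:
compound 1 `O=C(Nc1cccc([N+](=O)[O-])c1)N1CCN(S(=O)(=O)c2sccc2-c2ccccc2Oc2ccc(O)c(O)c2)CC1`: 4500 nM
compound 2 `Cc1ccc(-c2ccsc2S(=O)(=O)NCCNC(=O)Nc2cccc([N+](=O)[O-])c2)c(Oc2ccc(O)c(O)c2)c1`: 6000 nM
compound 3 `COc1ccc(Oc2ccccc2-c2ccsc2S(=O)(=O)N2CCN(C(=O)Nc3cccc([N+](=O)[O-])c3)CC2)cc1OC`: reported only as a limit, > 50000 nM

In a functional assay on HL-60 cells (Homo sapiens) for inhibition, read by CCK-8 assay, with a stated time of 48 h (a higher number here means a weaker inhibitor, a lower number a stronger inhibitor), compound 1 gives 4500 nM, the lowest of the two numbers shown. Compound 2 gives 6000 nM, which sits within the scatter of compound 1, so the two cannot be ordered. Compound 3 is reported only as a limit in this assay, > 50000 nM, and stands at the limit of > 50000 nM in this assay, at which 1 of the 3 values shown sits. Among the measured compounds shown here, the single measured step is an at least 11-fold higher number from compound 1 to compound 3 (1.04 log units; beyond the scatter); it changes the dihydroxyphenyl side of the molecule and says nothing about the urea end.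

Compound 4 `O=S(=O)(c1sccc1-c1ccccc1Oc1ccc(O)c(O)c1)N1CCN(C(=S)Nc2ccc(Cl)cc2)CC1` is not yet measured. It differs from compound 1 in a group of 10 heavy atoms (7 carbon, 1 nitrogen, 1 sulfur, 1 chlorine; one six-membered aromatic ring of carbon only) in place of a group of 12 heavy atoms (7 carbon, 2 nitrogen, 3 oxygen; one six-membered aromatic ring of carbon only), on an amine nitrogen in a ring. For the measured compounds named here, no measured step touches this part of compound 1, so there is nothing on which to predict a direction; the expectation is a step of no clear size beyond the scatter, with wide uncertainty. Compound 4 is therefore estimated at 5000 nM, with a range from 1500 nM to 20000 nM, which means an expected step of a 1.1-fold higher number from compound 1 to compound 4 (0.05 log units; within the scatter).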

Compound 4, half-maximal inhibitory concentration: 5500 nM
Compound 4: the middle estimate sits 1.1-fold (0.04 log units) below what was measured; the measured number falls inside the stated range.
By their numbers in this assay, from the lowest: compounds 1, 4 and 2 (each within the scatter of the next). At a limit, above all of these: compound 3.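

In this assay the change on the amine nitrogen in the ring gives a 1.2-fold higher number from compound 1 to compound 4 (0.09 log units; within the scatter), so this position accepts the group of 10 heavy atoms with sulfur and chlorine in place of (3-nitrophenyl)carbamoyl without any difference that can be read from the numbers. Among the compounds shown here, the only earlier step, an at least 11-fold higher number from compound 1 to compound 3 (1.04 log units; beyond the scatter), lay on the dihydroxyphenyl side of the molecule and was beyond the scatter, while this first step at the other end of the molecule is within it, so this end has now been changed once with no readable difference, on a single pair of compounds. No measurement shown here bears on why this exchange leaves the two compounds unordered.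

The sulfur, the chlorine and the loss of the nitro group all arrive in one exchange, so the compounds shown leave open what each contributes alone, and whether they offset one another. Also open, on these data alone, is how an amine or a carboxylic acid on that aromatic ring, or a longer chain in its place, would read in this assay.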